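A Fluorine Added to the Phenyl Ring of a Leukemia-Cell Inhibitor

The source may report more compounds than this note shows. Statements on the series, on what has been measured and on what is new or still open speak of the compounds shown alone.

Of the compounds shown here, three sharing one core have been tested in a functional assay on MV4-11 cells (Homo sapiens) for antiproliferative activity, read by CCK-8 assay, with a stated time of 72 h; a higher number here means a weaker inhibitor, a lower number a stronger inhibitor. Compound 1 `Cn1cc(-c2ccccc2)c2cc(C(=O)NCc3ccc(C(=O)Nc4ccccc4N)cc3)[nH]c2c1=O` gives 230 nM. Compound 2 `Cn1cc(-c2cc(C(C)(C)O)ccc2OC2CC2)c2cc(C(=O)NCc3ccc(C(=O)NO)cc3)[nH]c2c1=O`, which carries a hydroxamic acid in place of the aminophenyl amide at one end and a differently decorated phenyl ring, gives 420 nM; the numbers for compound 1 and compound 2 lie within the usual scatter of each other. Compound 3 `Cn1cc(-c2cc(C(C)(C)O)ccc2Oc2ccccc2)c2cc(C(=O)NCc3ccc(C(=O)Nc4ccccc4N)cc3)[nH]c2c1=O` gives 100 nM, a lower number than compound 1 by more than the scatter. Compound 1 therefore sits second from the top among the three numbers, separated clearly only from compound 3.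

Compound 4 `Cn1cc(-c2cccc(F)c2)c2cc(C(=O)NCc3ccc(C(=O)Nc4ccccc4N)cc3)[nH]c2c1=O` has not been measured yet. It differs from compound 1 in one place: fluoro in place of hydrogen on an aromatic carbon. Among the compounds with values here, no pair of measured compounds differs in just this way, so the step cannot be read from the data. Given that the change touches only one aromatic carbon of the phenyl ring, the step of a 1.2-fold lower number from compound 1 to compound 4 (0.06 log units; within the scatter) is expected to be modest and may well stay within the scatter, in either direction. Compound 4 is accordingly estimated to give about 200 nM, with a likely range from 90 nM to 450 nM.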

Compound 4, half-maximal inhibitory concentration: 210 nM
Estimate against measurement, compound 4: 1.1-fold (0.02 log units) below; the measured number falls inside the stated range.
By their numbers in this assay, from the lowest: compound 3; then compounds 4, 1 and 2 (each within the scatter of the next).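

Within the data shown here, compound 1 and compound 4 give the first comparison in this set that differs in only one place, and in this assay the step is a 1.1-fold lower number from compound 1 to compound 4 (0.04 log units; within the scatter), so the change from phenyl to 3-fluorophenyl cannot be told apart from the ordinary spread of repeated measurements. This carbon of the aromatic ring, meta to a large group, therefore accepts a single fluorine atom with no difference that this read-out can resolve, although one swap at one carbon says nothing yet about the rest of the ring. No measurement at hand offers an explanation for this flat result.

Going by these compounds, whether this tolerance extends beyond fluoro remains open: a chlorine atom, a methoxy group, an amine or a carboxylic acid on the same carbon could give a very different number, and the other carbons of the phenyl ring are just as uncertain. Compound 3 gives 100 nM, but it carries several changes at once, so its number cannot be assigned to any one group.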